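The compounds below may be only part of what the source reports. "The series", "measured", "known", "first", "only" and "open" are said of these compounds alone.

Measured compounds:
compound 1 `C=C[C@@](C)(CC[C@H]1C(C)=CC[C@H]2C(C)(C)CCC[C@]12C)O[C@@H]1O[C@@H](C)[C@@H](OC(C)=O)[C@H](O)[C@H]1O` — 3.8 ug/mL
compound 2 `C=C[C@@](C)(CC[C@H]1C(C)=CC[C@H]2C(C)(C)CCC[C@]12C)O[C@@H]1O[C@H](C)[C@H](O)[C@H](O)[C@H]1O` — 4.2 ug/mL
compound 3 `C=C[C@](C)(O)CC[C@H]1C(=C)[C@H](O)C[C@H]2C(C)(C)CCC[C@]12C` — only a limit of the assay, > 5 ug/mL

In a functional assay on XF498 cells (Homo sapiens) for cytotoxicity, read by sulforhodamine B assay (on this read-out lower numbers stand for an effect already at smaller amounts and higher numbers for an effect only at larger amounts of compound), compound 1 holds the lowest of the two numbers, but compound 2 sits within the scatter of it, so no order between them is claimed. Compound 3 reached only the limit (the limit of > 5 ug/mL in this assay, at which 1 of the 3 values shown sits).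

Compound 4 `C=C[C@@](C)(CC[C@H]1C(C)=CC[C@H]2C(C)(C)CCC[C@]12C)O[C@@H]1O[C@H](C)[C@H](OC(C)=O)[C@H](O)[C@H]1O` has not been measured. Compared with compound 1, (the two compounds have the same atoms and bonds and differ only in configuration as drawn: 2 of 9 stereo elements differ; a stereocentre at a saturated ring carbon is drawn S in compound 1 and R in compound 4; a stereocentre at a saturated ring carbon is drawn S in compound 1 and R in compound 4). For the measured compounds named here, no measured pair in this set differs only in configuration, so the size of such a step is unknown here; a change confined to two ring stereocentres is expected to give a step at most modest, likely none beyond the scatter. Compound 4 is therefore estimated at 4.5 ug/mL (range 2.5 ug/mL to 8 ug/mL), a step of a 1.2-fold higher number from compound 1 to compound 4 (0.07 log units; within the scatter), with some chance that this assay reports only a limit.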

Compound 4, concentration for half-maximal effect: 8.9 ug/mL
Compound 4: middle estimate off by 2.0-fold (0.30 log units), on the low side, outside the stated range (above it).
By their numbers in this assay, from the lowest: compounds 1 and 2 (each within the scatter of the next); then compound 4.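

Compound 4 shows that in this assay the configuration at these ring stereocentres alone can move the number beyond the scatter, with no atom or bond changed: the fact that compounds 1 and 4 differ only in the configuration as drawn. At this oxygen, acetyl in place of hydrogen also carries a cost, seen as a 2.1-fold higher number from compound 2 to compound 4 (0.33 log units; beyond the scatter), and the same comparison from the other side gives a 2.3-fold higher number from compound 1 to compound 4 (0.37 log units; beyond the scatter). Still open, going by these compounds, is whether one stereocentre or both account for the step, and what a benzoyl ester or an amine would do in place of the acetyl.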